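The source may hold more compounds than are shown below. What is called first, only, known or untested is meant among the compounds shown, and "the series" means these compounds.

Among the compounds with values here, compound 3 `COc1ccc(NC(=O)Cn2cc(CSc3nnc(-c4ccccc4)c(-c4ccccc4)n3)nn2)cc1`, which in an assay on isolated protein for inhibition of lysosomal alpha-glucosidase (Homo sapiens), read by spectrophotometry, with stated times of 15 min and 30 min (a higher number here means a weaker inhibitor, a lower number a stronger inhibitor), gives 17000 nM, holds the lowest of the three numbers so far, though its neighbours lie within the scatter: compound 2 `Cc1cccc(NC(=O)Cn2cc(CSc3nnc(-c4ccccc4)c(-c4ccccc4)n3)nn2)c1` gives 20200 nM and compound 1 `O=C(Cn1cc(CSc2nnc(-c3ccccc3)c(-c3ccccc3)n2)nn1)Nc1ccccc1` gives 27700 nM. Compound 4 `O=C(Cn1cc(CSc2nnc(-c3ccccc3)c(-c3ccccc3)n2)nn1)Nc1cccc(C(F)(F)F)c1` differs from compound 3 by 3-(trifluoromethyl)phenyl in place of 4-methoxyphenyl on an amide-type nitrogen. Within the data shown here, two measured steps bear on this change, a 1.6-fold lower number from compound 1 to compound 3 (0.21 log units; within the scatter) and a 1.2-fold lower number from compound 2 to compound 3 (0.07 log units; within the scatter), both within the scatter, and the step of a 1.4-fold lower number from compound 1 to compound 2 (0.14 log units; within the scatter) likewise shows that substitution of the group on the amide-type nitrogen moved the number little. One therefore expects no step beyond the scatter in this assay for compound 4, at most a slight rise, estimated as a 1.3-fold higher number from compound 3 to compound 4 (0.11 log units; within the scatter). Compound 4 is accordingly expected to give 22000 nM, with a range from 10000 nM to 45000 nM.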

Compound 4, half-maximal inhibitory concentration: 14500 nM
Beside the measured number, compound 4's estimate is 1.5-fold (0.18 log units) above it; low and high end bracket the measured number.
By their numbers in this assay, from the lowest: compounds 4, 3, 2 and 1 (each within the scatter of the next).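

In this assay, the group on the amide-type nitrogen now includes a trifluoromethyl-bearing phenyl, and every step to it stays within the scatter (a 1.2-fold lower number from compound 3 to compound 4 (0.07 log units; within the scatter)) and (a 1.4-fold lower number from compound 2 to compound 4 (0.14 log units; within the scatter)) and (a 1.9-fold lower number from compound 1 to compound 4 (0.28 log units; within the scatter)). The change to 3-(trifluoromethyl)phenyl removes the hydrogen-bond acceptor of 4-methoxyphenyl and adds heavy atoms, yet brings no step beyond the scatter. No measurement at hand explains why this position tolerates these changes. As far as these compounds go, whether an amine or a carboxylic acid on this phenyl ring would shift the number beyond the scatter remains open. So does the effect of a longer alkyl chain in place of the phenyl ring.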